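The compounds below may be only part of what the source reports. "The series", "measured", "known", "first", "only" and "open" are said of these compounds alone.

Measured compounds in the series:

compound 1 `Nc1scc(CN2CCN(c3cccc(Cl)c3Cl)CC2)c1C(=O)c1ccc(Cl)cc1` gives -77%
compound 2 `COc1ccc(N2CCN(Cc3csc(N)c3C(=O)c3ccc(Cl)cc3)CC2)cc1` gives -52%
compound 3 `Nc1scc(CN2CCN(c3ccc(OC(F)(F)F)cc3)CC2)c1C(=O)c1ccc(Cl)cc1` gives -74%

All three share one core and differ only in the aryl group on the ring nitrogen. In a functional assay on CHO cells with adenosine receptor A1 (Homo sapiens) as the target, read by cAMP accumulation and immunoassay, with a stated time of 6 min, tested at 10 uM (a higher number here means a weaker effect of the compound at the concentration tested, a lower number a stronger effect), compound 3 stands second highest of the three numbers: nearest is compound 1, a step of a number 3 percentage points higher from compound 1 to compound 3 (within the scatter), so the two cannot be ordered; furthest is compound 2, where a number 22 percentage points lower from compound 2 to compound 3 (beyond the scatter).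

Compound 4 `Nc1scc(CN2CCN(c3cccc(F)c3F)CC2)c1C(=O)c1ccc(Cl)cc1` is not yet measured. The change from compound 3 is 2,3-difluorophenyl in place of 4-(trifluoromethoxy)phenyl on an amine nitrogen in a ring.

For the measured compounds named here, the steps that bear on it are those exchanging the aryl group: a number 25 percentage points higher from compound 1 to compound 2 (beyond the scatter) and a number 3 percentage points higher from compound 1 to compound 3 (within the scatter). The 2,3-dichlorophenyl of compound 1 and the 4-(trifluoromethoxy)phenyl of compound 3 sit together, with only the 4-methoxyphenyl of compound 2 clearly higher. A 2,3-difluorophenyl resembles the substitution of compound 1, so no step beyond the scatter is expected in this assay, with a small allowance toward higher numbers.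

Compound 4 is estimated at -70%, range -85% to -50%. The expected step is a number 4 percentage points higher from compound 3 to compound 4 (within the scatter).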

Compound 4, a percentage reported as activity, at one concentration (the size of the read-out at that concentration, not a potency): -79%
Compound 4: the middle estimate sits 9 percentage points above what was measured; measured number inside the range.
By their numbers in this assay, from the lowest: compounds 4, 1 and 3 (each within the scatter of the next); then compound 2.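

In this assay the exchange of halogen on the 2,3-disubstituted aryl group gives a number 2 percentage points lower from compound 1 to compound 4 (within the scatter) and thus no readable change, so fluorine and chlorine cannot be told apart here. The exchange for the 4-(trifluoromethoxy)phenyl gives a number 5 percentage points lower from compound 3 to compound 4 (within the scatter) and leaves compound 1, compound 3 and compound 4 as one unordered group, although the smaller 2,3-difluorophenyl differs from the 4-(trifluoromethoxy)phenyl in both size and substitution, while the 4-methoxyphenyl remains apart with a number 27 percentage points lower from compound 2 to compound 4 (beyond the scatter) as a third aryl comparison beyond the scatter. Nothing available accounts for compound 2 standing apart from the other three.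

From the compounds shown here alone, whether an unsubstituted phenyl or an aryl group carrying an amine or a carboxylic acid would fall with compound 4 or with compound 2 stays open. Going by these compounds, the effect of replacing the 4-chlorophenyl ketone of the shared core also stays open.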